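Carboxy in place of hydroxy: the step from compound 1 to compound 4

The compounds below may be only part of what the source reports. "The series", "measured", "known", "first", "only" and "open" are said of these compounds alone.

Compound 1 `COc1ccc(S(=O)(=O)N2CCc3cccc(Nc4ccc(O)cc4)c32)cc1` is the starting point of this comparison. In a functional assay on KB cells (Homo sapiens) for antiproliferative activity (on this read-out higher numbers stand for weaker inhibition and lower numbers for stronger inhibition), compound 1 gives 239 nM, the highest of the three numbers measured. Compound 2 `COc1ccc(S(=O)(=O)N2CCc3cccc(Nc4ccc([N+](=O)[O-])cc4)c32)cc1` gives 101 nM in this assay, and compound 3 `COc1ccc(S(=O)(=O)N2CCc3cccc(Nc4ccc(C#N)cc4)c32)cc1` gives 49.7 nM in the same read-out. Both measured steps away from compound 1 replace the same hydroxy group: the change to nitro gives a 2.4-fold lower number from compound 1 to compound 2 (0.37 log units; beyond the scatter), and the change to cyano gives a 4.8-fold lower number from compound 1 to compound 3 (0.68 log units; beyond the scatter), while between the two new groups there is a 2.0-fold lower number from compound 2 to compound 3 (0.31 log units; beyond the scatter).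

Compound 4 `COc1ccc(S(=O)(=O)N2CCc3cccc(Nc4ccc(C(=O)O)cc4)c32)cc1` has not yet been measured. It differs from compound 1 by carboxy in place of hydroxy on an aromatic carbon. For the measured compounds named here, no measured step introduces a carboxy group, so neither of the steps from compound 1 tells directly what this change will do; they show only that exchanging the hydroxy for another group at this position has so far moved the number lower by a modest amount. Because the closest comparisons are a 2.4-fold lower number from compound 1 to compound 2 (0.37 log units; beyond the scatter) and a 4.8-fold lower number from compound 1 to compound 3 (0.68 log units; beyond the scatter), the expectation for compound 4 is loose: a step within the scatter or somewhat higher seems most likely. The estimated result is a 1.5-fold higher number from compound 1 to compound 4 (0.17 log units; within the scatter). Compound 4 is therefore expected to give about 350 nM in this assay, within a range of 120 nM to 1100 nM.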

Compound 4, half-maximal inhibitory concentration: 846 nM
Beside the measured number, compound 4's estimate is 2.4-fold (0.38 log units) below it; low and high end bracket the measured number.
By their numbers in this assay, from the lowest: compound 3; then compound 2; then compound 1; then compound 4.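

In this assay, carboxy in place of hydroxy gives a 3.5-fold higher number from compound 1 to compound 4 (0.55 log units; beyond the scatter), so replacing the hydroxy at this position does not always lower the number: nitro in compound 2 and cyano in compound 3 lowered it, whereas carboxy raised it. For the compounds shown here, the position also proves more sensitive to the choice of group than the earlier compounds showed, with an 8.4-fold higher number from compound 2 to compound 4 (0.92 log units; beyond the scatter) and a 17-fold higher number from compound 3 to compound 4 (1.23 log units; beyond the scatter), the latter being a large step between two groups on the same aromatic carbon. Nothing given here accounts for this change of direction.

The compounds shown leave open whether the higher number belongs to the carboxy group specifically or would also appear with its methyl ester, a primary amide or an aminomethyl group on the same aromatic carbon. They also leave open how a group such as methoxy or fluorine would fall in the order running from compound 3 through compound 2 and compound 1 to compound 4, and whether that order would hold with any other part of the shared core changed.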